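This account rests on a few compounds, and the source may have more. Where it says the series, first, only, none or still open, it means among the compounds named here.

Measured compounds:
compound 1 `CC1CCN(C2CCN(S(=O)(=O)c3nccn3C)CC2)CC1` — > 5000 nM
compound 2 `COc1ccc(-c2ccccc2S(=O)(=O)N2CCC(N3CCC(C)CC3)CC2)cc1` — 1000 nM

In a functional assay on DLD-1 cells (Homo sapiens) for antiproliferative activity, read by CellTiter-Glo, with a stated time of 72 h (a higher number here means a weaker inhibitor, a lower number a stronger inhibitor), compound 1 gives > 5000 nM, and this is a limit of the assay, not a number. Compound 1 therefore stands at the limit of > 5000 nM in this assay, at which 1 of the 2 values shown sits. Compound 2, the other measured compound, gives 1000 nM in this assay; its structure differs from compound 1 in more than one place, so nothing more than the two values themselves is drawn from the pair.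

The step followed here leads to compound 3 `CC1CCN(C2CCN(S(=O)(=O)c3ccc(Cl)cc3Cl)CC2)CC1`, which is not yet measured. The change is 2,4-dichlorophenyl in place of 1-methyl-1H-imidazol-2-yl on a sulfonyl sulfur. For the measured compounds named here, no measured step accompanies it. Since compound 1 sits only at a limit, the step cannot be sized from the known numbers; the estimate for compound 3 is merely that the step will be an at least 2.0-fold lower number from compound 1 to compound 3 (0.30 log units; that floor lies within the scatter), an expected gain beyond the scatter, toward a measurable value. Compound 3 is estimated at 2500 nM, with a range from 600 nM to 10000 nM.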

Compound 3, half-maximal inhibitory concentration: 1 nM
For compound 3 the middle estimate is 2500-fold (3.40 log units) above the measured one, outside the stated range (below it).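

In this assay the group on the sulfonyl sulfur proves able to carry a very large change in activity: 2,4-dichlorophenyl in place of 1-methyl-1H-imidazol-2-yl gives an at least 5000-fold lower number from compound 1 to compound 3 (3.69 log units; beyond the scatter) with the rest of the structure unchanged. This single change moves the series from a limit of the assay to a measured value, something the two earlier compounds could not show. The size of the step is a floor and not an exact figure, because compound 1 stands at a limit: the limit of > 5000 nM in this assay, at which 1 of the 3 values shown sits.

The change replaces the whole ring at once, so the compounds shown do not separate the contribution of the chlorine atoms from that of the carbon-only ring. As far as these compounds go, whether an unsubstituted phenyl, or a phenyl carrying an amine or a carboxylic acid, would hold this activity stays open.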